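The source may hold more compounds than are shown below. What is called first, only, known or untested is meant among the compounds shown, and "the series" means these compounds.

Measured so far:
Compound 1 `O=C(O)c1cc(-c2cccc(COc3ccc4c(=O)n(C5CCCC5)sc4c3)c2)ccc1F` — 240 nM in an assay on HEK293 cells for positive allosteric modulation of metabotropic glutamate receptor 2 (Rattus norvegicus), read by thallium flux; on this read-out lower numbers stand for an effect already at smaller amounts and higher numbers for an effect only at larger amounts of compound
Compound 2 `O=C(O)c1cc(-c2cccc(COc3ccc4c(=O)n(C5CCCC5)sc4c3)c2)cc([N+](=O)[O-])c1` — 200 nM in this assay

These two compounds share the same core and differ only in the substituents on the outer aromatic ring that carries the carboxylic acid. In this assay compound 1 gives 240 nM, the higher of the two numbers, and compound 2 gives 200 nM; the gap between them lies within the scatter of repeated measurements, so the two values should be read as equivalent.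

Compound 3 `Cc1ccc(C(=O)O)cc1-c1cccc(COc2ccc3c(=O)n(C4CCCC4)sc3c2)c1` has not yet been measured. Compared with compound 1, its outer ring is changed as follows: 5-carboxy-2-methylphenyl in place of 3-carboxy-4-fluorophenyl on an aromatic carbon. The names of the two groups show that the carboxylic acid and the small substituent are arranged differently around the ring, so this is a rearrangement of the acid-bearing ring rather than a simple exchange of one small group for another.

Among the measured compounds shown here, no measured pair shows a change of this kind, so the direction is open. A modest shift toward a higher number, around the edge of the scatter, is expected for compound 3, giving an estimated 400 nM with a range from 120 nM to 1300 nM; the expected step of a 1.7-fold higher number from compound 1 to compound 3 (0.22 log units; within the scatter) is small.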

Compound 3, half-maximal effective concentration: 740 nM
For compound 3 the middle estimate is 1.9-fold (0.27 log units) below the measured one; the measured number falls inside the stated range.
By their numbers in this assay, from the lowest: compounds 2 and 1 (each within the scatter of the next); then compound 3.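

Within this assay, placing 5-carboxy-2-methylphenyl where 3-carboxy-4-fluorophenyl stood gives a 3.1-fold higher number from compound 1 to compound 3 (0.49 log units; beyond the scatter), the first measured step on this outer ring, and it lies beyond the usual scatter. The result therefore shows that this ring, attached through an aromatic carbon, is not free to change without consequence, although the size of the step is modest. This single swap removes the fluorine, adds a methyl group, and rearranges the ring's substituents together, and nothing available explains why the number rises.

The compounds shown do not separate the loss of the fluorine, the arrival of the methyl group, and the new arrangement around the ring, so the contribution of each remains unknown. A ring with the arrangement of compound 3 but carrying a chlorine atom or a methoxy group in place of the methyl group would begin to show whether the identity of that small substituent matters, or whether the arrangement alone accounts for the step.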